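The source may hold more compounds than are shown below. What is called first, only, known or untested is meant among the compounds shown, and "the series" means these compounds.

Measured compounds:
compound 1 `Cc1nc(Cl)sc1S(=O)(=O)N1CCC(N2CCC(C)CC2)CC1` — 1.6 nM
compound 2 `CC1CCN(C2CCN(S(=O)(=O)c3ccc(C#N)cc3)CC2)CC1` — 2800 nM
compound 3 `CC1CCN(C2CCN(S(=O)(=O)c3cccc(Cl)c3)CC2)CC1` — > 5000 nM

In a functional assay on DLD-1 cells (Homo sapiens) for antiproliferative activity, read by CellTiter-Glo, with a stated time of 72 h (a lower number here means a stronger inhibitor, a higher number a weaker inhibitor), compound 1 gives 1.6 nM and compound 2 gives 2800 nM. For compound 3 the assay reports only a limit, > 5000 nM, placing it at the limit of > 5000 nM in this assay, at which 1 of the 3 values shown sits. The steps leading to it were an at least 3100-fold higher number from compound 1 to compound 3 (3.49 log units; beyond the scatter) and an at least 1.7-fold higher number from compound 2 to compound 3 (0.25 log units; that floor lies within the scatter); both phenyl replacements of the thiazolyl group on the sulfonyl sulfur gave large losses.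

Compound 4 `CC1CCN(C2CCN(S(=O)(=O)c3cc(Cl)cc(Cl)c3)CC2)CC1` differs from compound 3 by chloro in place of hydrogen on an aromatic carbon. Within the data shown here, no measured step adds a substituent to an aryl ring already in place, so the bearing steps are only those above, which put compound 3 at the floor. Compound 4 is expected to stay there, with no step beyond the scatter: a step that the limit leaves unreadable from compound 3 to compound 4. Estimate for compound 4: 8000 nM, range 3000 nM to 30000 nM.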

Compound 4, half-maximal inhibitory concentration: 3400 nM
Beside the measured number, compound 4's estimate is 2.4-fold (0.37 log units) above it; measured number inside the range.
By their numbers in this assay, from the lowest: compound 1; then compounds 2 and 4 (each within the scatter of the next). At a limit, above all of these: compound 3.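

The added chloro gives an at least 1.4-fold lower number from compound 3 to compound 4 (0.16 log units; that floor lies within the scatter), which cannot be read as a change, as compound 3 is held at a limit: the limit of > 5000 nM in this assay, at which 1 of the 4 values shown sits.

With a 1.2-fold higher number from compound 2 to compound 4 (0.08 log units; within the scatter), 3,5-dichlorophenyl and 4-cyanophenyl are not separated on the sulfonyl sulfur. With a 2100-fold higher number from compound 1 to compound 4 (3.33 log units; beyond the scatter), the added chloro leaves the phenyl compounds far from the 2-chloro-4-methyl-1,3-thiazol-5-yl group of compound 1.

Open, as far as these compounds go, is which part of that group carries the difference. Also open, from the compounds shown here alone, is whether a phenyl bearing an amine or a carboxylic acid would come any closer to compound 1.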